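This account rests on a few compounds, and the source may have more. Where it says the series, first, only, none or still open, it means among the compounds named here.

In a functional assay on HCT-116 cells (Homo sapiens) for antiproliferative activity, with a stated time of 72 h (a higher number here means a weaker inhibitor, a lower number a stronger inhibitor), compound 1 (`Nc1ncnn2c([C@@H]3O[C@H](CO)[C@@H](O)[C@H]3O)cc(-c3ccccc3)c12`) gives 82600 nM. Compound 2 (`COc1ccc(-c2cc([C@@H]3O[C@H](CO)[C@@H](O)[C@H]3O)n3ncnc(N)c23)cc1`), which adds a methoxy group to the aromatic ring on the shared core, gives 47100 nM. This is a 1.8-fold lower number from compound 1 to compound 2 (0.24 log units; within the scatter), so the two compounds cannot be told apart on these numbers, and compound 2 stands level with compound 1.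

Compound 3 (`Nc1ncnn2c([C@@H]3O[C@H](CO)[C@@H](O)[C@H]3O)cc(-c3ccoc3)c12`) has not yet been measured. It carries furan-3-yl in place of 4-methoxyphenyl on an aromatic carbon. Among the measured compounds shown here, only one measured step bears on this change, and it bears weakly. That step adds a methoxy group and leaves the aromatic ring in place, whereas here the whole ring is exchanged. For the measured compounds named here, no measured compound carries furan-3-yl, so the size of the new step is poorly constrained. A move to a lower number in this assay, beyond the scatter, is expected, but this is a cautious judgement and the range must stay wide. The expected change is a 9.4-fold lower number from compound 2 to compound 3 (0.97 log units; beyond the scatter). For compound 3, the estimate is 5000 nM, with an expected range of 200 nM to 60000 nM.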

Compound 3, half-maximal inhibitory concentration: 1400 nM
The estimate for compound 3 lay 3.6-fold (0.55 log units) above the measured number; the range from low to high includes it.
By their numbers in this assay, from the lowest: compound 3; then compounds 2 and 1 (each within the scatter of the next).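

In this assay, the aromatic carbon two ring bonds from the ring nitrogen proves sensitive to which ring it carries: furan-3-yl in place of 4-methoxyphenyl gives a 34-fold lower number from compound 2 to compound 3 (1.53 log units; beyond the scatter) and furan-3-yl in place of phenyl gives a 59-fold lower number from compound 1 to compound 3 (1.77 log units; beyond the scatter) in the same direction. Among the compounds shown here, the earlier pair showed only that adding a methoxy group to the phenyl ring produced no step beyond the scatter, whereas exchanging the ring itself does produce one, and compounds 1 and 2 both point to that conclusion. Nothing available here explains why this exchange has such a large effect on the antiproliferative read-out.

With furan-3-yl as the only five-membered ring shown, the compounds cannot separate the effect of a smaller ring from that of having oxygen in the ring, or show whether the point of attachment matters. Thiophen-3-yl, pyrrol-3-yl and furan-2-yl groups at this place would address those questions, while a simple methyl group would test whether any aromatic ring is needed there at all.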